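The compounds below may be only part of what the source reports. "The series", "measured", "known", "first", "only" and "open" are said of these compounds alone.

Working notes on the series.

Compound 2 `O=C1c2ccccc2S(=O)(=O)N1CCCCCCN1CCN(c2cccc(Cl)c2Cl)CC1` gives 72 nM in an assay on HEK293 cells for displacement of a labelled ligand from 5-hydroxytryptamine receptor 6 (Homo sapiens) (on this read-out higher numbers stand for weaker inhibition and lower numbers for stronger inhibition), and holds the lowest number of the three measured compounds. Compound 1 `O=C1c2ccccc2S(=O)(=O)N1CCCCCN1CCN(c2ccc(Cl)cc2)CC1` gives 703 nM and compound 3 `O=C1c2ccccc2S(=O)(=O)N1CCCCCN1CCN(c2ccccc2)CC1` gives 1840 nM; compound 2 differs from both in more than one place, so only the gaps between the values can be read, and both are beyond the scatter. Compound 4 `COc1ccccc1N1CCN(CCCCCCN2C(=O)c3ccccc3S2(=O)=O)CC1` has not yet been measured. It differs from compound 2 in one place: 2-methoxyphenyl in place of 2,3-dichlorophenyl on an amine nitrogen in a ring.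

Among the compounds with values here, the only single-point step measured so far is a 2.6-fold higher number from compound 1 to compound 3 (0.42 log units; beyond the scatter), which shows that taking a chloro away from the aromatic ring in compound 1 costs a modest amount of binding. Within the data shown here, compound 4 gives up both chlorines of compound 2 and takes a methoxy group instead, and no measured compound carries a methoxy on that ring, so the step that methoxy itself contributes is unknown. Among the measured compounds shown here, the loss of both chlorines is expected to weigh more than the single loss seen from compound 1 to compound 3, and the methoxy is treated as an open term.

Compound 4 is therefore expected to land at 250 nM, a step of a 3.5-fold higher number from compound 2 to compound 4 (0.54 log units; beyond the scatter) towards weaker inhibition, within a range of 80 nM to 800 nM.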

Compound 4, inhibition constant: 779 nM
The estimate for compound 4 lay 3.1-fold (0.49 log units) below the measured number; the measured number falls inside the stated range.
By their numbers in this assay, from the lowest: compound 2; then compounds 1 and 4 (each within the scatter of the next); then compound 3.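

Within the data shown here, on the amine nitrogen in the ring, 2-methoxyphenyl in place of 2,3-dichlorophenyl gives an 11-fold higher number from compound 2 to compound 4 (1.03 log units; beyond the scatter) in this assay, the first measured change at this position that replaces the whole aromatic group rather than removing a single chloro. This large step compares with the modest 2.6-fold higher number from compound 1 to compound 3 (0.42 log units; beyond the scatter) and shows that this position can carry a large part of the binding measured in the series. The heavy-atom count stays the same across the change, so the step arises with no change in that count, while the entering group brings a hydrogen-bond acceptor and removes both chlorines. Nothing measured on these compounds bears on why the step has this size.

Going by these compounds, how much of the step belongs to the loss of the chlorines and how much to the arrival of the methoxy remains open, and a plain phenyl or a 2-chlorophenyl group on the chain of compound 2 would separate the two terms. Also open, on these data alone, is whether an ethoxy group or a hydroxy group in place of the methoxy would move the number in either direction.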